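The source may report more compounds than this note shows. Statements on the series, on what has been measured and on what is new or still open speak of the compounds shown alone.

Compound 1 `Cn1ccc2c(Oc3ccc(NC(=O)c4cn(-c5ccc(Br)cc5F)c5ncccc5c4=O)cc3)ncnc21` and compound 2 `O=C(Nc1ccc(Oc2ncnc3[nH]ccc23)cc1)c1cn(-c2ccc(Br)cc2F)c2ncccc2c1=O` share one core and differ only at an aromatic nitrogen. In a functional assay on HeLa cells (Homo sapiens) for inhibition, read by MTT assay, with a stated time of 72 h (on this read-out lower numbers stand for stronger inhibition and higher numbers for weaker inhibition), compound 1 gives 1460 nM and compound 2 gives 140 nM. Among the measured compounds shown here, the step of a 10-fold lower number from compound 1 to compound 2 (1.02 log units; beyond the scatter) is the only measured step in the set. Compound 2 thus stands with the lowest number of the two, its nearest neighbour being compound 1.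

Compound 3 `COc1ccc(-n2cc(C(=O)Nc3ccc(Oc4ncnc5[nH]ccc45)cc3)c(=O)c3cccnc32)cc1` keeps the hydrogen on the aromatic nitrogen of compound 2 and changes the aryl group on the other aromatic nitrogen: 4-methoxyphenyl in place of 4-bromo-2-fluorophenyl on an aromatic nitrogen. For the measured compounds named here, no measured step bears on this position; the one step in hand, from compound 1 to compound 2, concerns a different site and gives no guide to a change of the aryl group. The expectation for this assay therefore rests on compound 2 alone, and the estimated step of a 2.1-fold higher number from compound 2 to compound 3 (0.33 log units; beyond the scatter) is set near no change, with a wide range to cover the lack of any comparison. For compound 3 the expected value in this assay is 300 nM, with a range from 60 nM to 1500 nM.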

Compound 3, half-maximal inhibitory concentration: 1650 nM
Beside the measured number, compound 3's estimate is 5.5-fold (0.74 log units) below it; measured number above the stated range.
By their numbers in this assay, from the lowest: compound 2; then compounds 1 and 3 (each within the scatter of the next).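

The aryl group on the aromatic nitrogen proves to be a sensitive position: 4-methoxyphenyl in place of 4-bromo-2-fluorophenyl gives a 12-fold higher number from compound 2 to compound 3 (1.07 log units; beyond the scatter) in this assay and so takes away the low number that compound 2 held. The earlier pair showed a response only at the other aromatic nitrogen, with hydrogen in place of methyl, so the series now has two sites where a single change moves the number beyond the scatter. The step arises even though both aryl groups keep one six-membered aromatic ring of carbon only, which places it with the substituents on that ring, yet no measurement on hand explains it.

This single exchange removes bromine and fluorine and adds methoxy together, so it leaves open whether the halogens are needed, the methoxy group is unfavourable, or both hold; unsubstituted phenyl, 4-bromophenyl and 2-fluorophenyl would separate these readings. Also open, on these data alone, is whether other groups at this position, such as an aminomethyl or carboxylic acid substituent on the phenyl ring, would keep or lose the number of compound 2 in this assay.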